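Swapping the Pyrazole for a Methylthiazole: What to Expect

The source may hold more compounds than are shown below. What is called first, only, known or untested is meant among the compounds shown, and "the series" means these compounds.

Compound 3 `Cc1ccc(CNC(=O)c2cccc(C(C)Oc3cccnc3Nc3cnn(CC#N)c3)c2)cc1` holds the highest of the two numbers in hand: in a functional assay on HCC78 cells (Homo sapiens) for antiproliferative activity, read by MTT assay, with a stated time of 48 h (a higher number here means a weaker inhibitor, a lower number a stronger inhibitor), compound 3 gives 57400 nM. Compound 1 `Cc1ccc(CNC(=O)c2cccc(C(C)Oc3cccnc3Nc3ncccn3)c2)cc1` gives only a limit in this assay, > 100000 nM, so no number is known for it. Compound 2 `Cc1ccc(CNC(=O)c2cccc(C(C)Oc3cccnc3Nc3nccs3)c2)cc1` gives 27100 nM. The step to compound 4 `Cc1ccc(CNC(=O)c2cccc(C(C)Oc3cccnc3Nc3ncc(C)s3)c2)cc1` is 5-methyl-1,3-thiazol-2-yl in place of 1-(cyanomethyl)-1H-pyrazol-4-yl on a nitrogen on an aromatic ring. The measured step that bears on it runs the other way, a 2.1-fold higher number from compound 2 to compound 3 (0.33 log units; beyond the scatter), and a second one starts from a limit, an at least 3.6-fold lower number from compound 1 to compound 2 (0.56 log units; beyond the scatter). Since the change is largely that step reversed, with a methyl added, a modest lowering is expected, about a 2.6-fold lower number from compound 3 to compound 4 (0.42 log units; beyond the scatter). Compound 4 is therefore estimated at 22000 nM, with a likely range from 8000 nM to 60000 nM.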

Compound 4, half-maximal inhibitory concentration: 14800 nM
For compound 4 the middle estimate is 1.5-fold (0.17 log units) above the measured one; low and high end bracket the measured number.
By their numbers in this assay, from the lowest: compounds 4 and 2 (each within the scatter of the next); then compound 3. At a limit, above all of these: compound 1.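

In this assay, 5-methyl-1,3-thiazol-2-yl in place of 1-(cyanomethyl)-1H-pyrazol-4-yl on this nitrogen gives a 3.9-fold lower number from compound 3 to compound 4 (0.59 log units; beyond the scatter), so the gain seen with the 1,3-thiazol-2-yl group survives adding a methyl to it. That methyl, in place of hydrogen on an aromatic carbon, gives a 1.8-fold lower number from compound 2 to compound 4 (0.26 log units; within the scatter), so compound 2 and compound 4 cannot be told apart. The step from the pyrimidin-2-yl group is an at least 6.7-fold lower number from compound 1 to compound 4 (0.82 log units; beyond the scatter), but compound 1 has only a limit, not a number: the limit of > 100000 nM in this assay, at which 1 of the 4 values shown sits.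

Still open, on these data alone, is what a longer chain such as ethyl, an amine or a carboxylic acid in place of that methyl would do in this assay.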